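The source may hold more compounds than are shown below. What is called first, only, known or untested is meant among the compounds shown, and "the series" means these compounds.

Compound 1 `Cc1cccc(C)c1CN[C@]1(CCC(C)(C)C)C(=O)C(C2=NS(=O)(=O)c3cc(NS(C)(=O)=O)ccc3N2)=C(O)c2ccccc21` gives 4210 ng.h/mL in an ADME assay on the whole organism (plasma, strain Sprague-Dawley) for pharmacokinetics, with Rattus norvegicus as the target, at a dose of 5 mg/kg by the oral route; on this read-out lower numbers stand for lower exposure and higher numbers for higher exposure at the dose given.
Compound 2 `CC(C)CC[C@@]1(NCc2ccccc2)C(=O)C(C2=NS(=O)(=O)c3cc(NS(C)(=O)=O)ccc3N2)=C(O)c2ccccc21` gives 600 ng.h/mL in this assay.

Compound 1 stands highest of the two numbers, and compound 2 sits well below it, beyond the usual scatter. Compound 3 `Cc1cccc(C)c1CNC1(CCC(C)(C)C)C(=O)C(C2=NS(=O)(=O)c3cc(NS(C)(=O)=O)ccc3N2)=C(O)c2ccccc21` keeps every atom and bond of compound 1 and differs only in how one stereocentre is drawn: the two compounds have the same atoms and bonds; at least one stereo element is drawn with a configuration in one of them and without one in the other: 1 of 1 stereo elements differ; a stereocentre at a saturated ring carbon is drawn S in compound 1 and without a configuration in compound 3. Within the data shown here, no measured step of this kind is available, so only a small drop or no change beyond the scatter is expected. For compound 3 the expected value is 3000 ng.h/mL, with a range from 1200 ng.h/mL to 7000 ng.h/mL. This amounts to an expected step of a 1.4-fold lower number from compound 1 to compound 3 (0.15 log units; within the scatter).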

Compound 3, area under the concentration-time curve: 3500 ng.h/mL
Compound 3: the middle estimate sits 1.2-fold (0.07 log units) below what was measured; low and high end bracket the measured number.
By their numbers in this assay, from the lowest: compound 2; then compounds 3 and 1 (each within the scatter of the next).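

Compound 1 has a defined configuration at this saturated ring carbon and compound 3 has none, and the step is a 1.2-fold lower number from compound 1 to compound 3 (0.08 log units; within the scatter) in this assay. Among these compounds, this is the first pair to isolate this stereocentre, and on this read-out its two drawings cannot be told apart. The pair differs in only one respect: the fact that one of compounds 1 and 3 is drawn with a defined configuration and the other without, at the place where they differ

Still open, from the compounds shown here alone, is what exposure a compound drawn with the opposite configuration at this carbon alone would give. So is the effect of a single change elsewhere, such as adding a carboxylic acid to the shared core.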